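This account rests on a few compounds, and the source may have more. Where it says the series, first, only, none or still open, it means among the compounds named here.

In an ADME assay on BJ cells (Homo sapiens) for cytotoxicity, read by MTT assay, with a stated time of 72 h (on this read-out higher numbers stand for weaker inhibition and lower numbers for stronger inhibition), compound 1 (`Oc1ccccc1CNc1ncnc2c1ncn2C1CCCCO1`) gives > 100000 nM as a limit of the assay, not a number. Compound 2 (`Oc1ccc(CNc2ncnc3c2ncn3C2CCCCO2)cc1`) gives > 100000 nM as a limit as well. Compound 3 (`Oc1ccccc1CNc1ncnc2c1ncn2C1CCCO1`) gives > 100000 nM as a limit too. Among the measured compounds shown here, the series so far stands at the limit of > 100000 nM in this assay, at which 3 of the 3 values shown sit, without exception. Compound 4 (`COc1ccccc1CNc1ncnc2c1ncn2C1CCCO1`) comes from compound 3 through methyl in place of hydrogen on an oxygen on an aromatic ring as methyl in place of hydrogen on an oxygen on an aromatic ring, hydroxy to methoxy. The nearest measured steps, a step that the two limits leave unreadable from compound 1 to compound 2 and a step that the two limits leave unreadable from compound 1 to compound 3 here, have no readable size, and neither replaces that hydrogen. No step beyond the scatter is therefore expected, in either direction. The expected step is a number no higher from compound 3 to compound 4 (the limit leaves the size open) in this assay on this reading. Compound 4 is estimated at 100000 nM with an expected range of 40000 nM to 200000 nM and will probably return only a limit.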

Compound 4, half-maximal inhibitory concentration: > 100000 nM
Compound 4 ended at the assay's limit; the forecaster's own chance of this, stated with the estimate: 85%; the middle value lies on the limit itself.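

No step can be read between compound 3 and compound 4 in this assay: both values are limits of the assay, not numbers. The compounds shown leave open whether any change on the shared core would give a readable number, with every value so far at one limit: the limit of > 100000 nM in this assay, at which 4 of the 4 values shown sit.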